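The source may report more compounds than this note shows. Statements on the series, on what has been measured and on what is new or still open speak of the compounds shown alone.

Measured so far in an ADME assay for permeability, using PAMPA, with a stated time of 30 min, at pH 7.4; a lower number here means that the compound crosses the layer more slowly, a higher number that the compound crosses the layer faster:
compound 1 `COc1ccc(F)cc1CNCCCNc1ccnc2cc(-c3ccc(F)cc3)ccc12` gives 237 10^-6 cm/s
compound 2 `COc1ccc(F)cc1CNCCCNc1ccnc2cc(Oc3cccc(N(C)C)c3)ccc12` gives 317 10^-6 cm/s

Among the compounds with values here, compound 2 has one of only two numbers, and its distance from compound 1 is a 1.3-fold higher number from compound 1 to compound 2 (0.13 log units; within the scatter), a gap that falls within the scatter. Compound 3 `COc1ccc(-c2ccc3c(NCCCNCc4cc(F)ccc4OC)ccnc3c2)cc1` has not been measured; it differs from compound 2 by 4-methoxyphenyl in place of 3-(dimethylamino)phenoxy on an aromatic carbon. Within the data shown here, the one measured step that touches this same position, a 1.3-fold higher number from compound 1 to compound 2 (0.13 log units; within the scatter), stayed within the scatter, so for compound 3 no movement beyond the scatter in this assay is expected, and the expected step is a 1.2-fold lower number from compound 2 to compound 3 (0.09 log units; within the scatter). Compound 3 is estimated at 260 10^-6 cm/s, between 150 10^-6 cm/s and 450 10^-6 cm/s.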

Compound 3, apparent permeability: 237 10^-6 cm/s
Estimate against measurement, compound 3: 1.1-fold (0.04 log units) above; the measured number falls inside the stated range.
By their numbers in this assay, from the lowest: compounds 1, 3 and 2 (each within the scatter of the next).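

In this assay, the change to 4-methoxyphenyl gives a 1.3-fold lower number from compound 2 to compound 3 (0.13 log units; within the scatter), and the swap of fluoro for methoxy on the aromatic ring gives no change at the digits printed from compound 1 to compound 3 (within the scatter), so neither step leaves the scatter. This position has now taken three different groups without a change beyond the scatter, including two that differ only in that one substituent. Nothing at hand explains why these numbers stay so close.

All three groups carry an aromatic ring of carbon only. As far as these compounds go, how a group without such a ring, such as a simple amine or a carboxylic acid, would behave here remains open.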